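Benzyl Replaces Cyclopropyl on the Chain Carbon

This account rests on a few compounds, and the source may have more. Where it says the series, first, only, none or still open, it means among the compounds named here.

Compound 1 `O=C1NC(=O)/C(=C/C(c2ccc(-c3ccc4cccc(F)c4c3)[nH]c2=O)C2CCCCC2)O1`: 8 nM
Compound 2 `O=C1NC(=O)/C(=C/C(c2ccc(-c3ccc4cccc(F)c4c3)[nH]c2=O)C2CC2)O1`: 33 nM

Of the compounds shown here, two sharing one core have been measured in a functional assay on CHO cells for antagonist activity at prostaglandin E2 receptor EP3 subtype (Homo sapiens), read by cAMP accumulation, with a stated time of 30 min; on this read-out higher numbers stand for weaker inhibition and lower numbers for stronger inhibition. Compound 1 `O=C1NC(=O)/C(=C/C(c2ccc(-c3ccc4cccc(F)c4c3)[nH]c2=O)C2CCCCC2)O1` gives 8 nM in this assay, and compound 2 `O=C1NC(=O)/C(=C/C(c2ccc(-c3ccc4cccc(F)c4c3)[nH]c2=O)C2CC2)O1` gives 33 nM. Among these two numbers compound 2 stands highest; its nearest neighbour is compound 1, and the step of a 4.1-fold higher number from compound 1 to compound 2 (0.62 log units; beyond the scatter) lies beyond the scatter.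

The next compound, compound 3 `O=C1NC(=O)/C(=C/C(Cc2ccccc2)c2ccc(-c3ccc4cccc(F)c4c3)[nH]c2=O)O1`, follows from compound 2 by a single change: benzyl in place of cyclopropyl on a saturated chain carbon bound to an aromatic carbon and a double-bonded chain carbon. Within the data shown here, only one measured step bears on this position, namely a 4.1-fold higher number from compound 1 to compound 2 (0.62 log units; beyond the scatter), where the smaller ring on that chain carbon went with a weaker result. Benzyl returns a larger group to the same place, though a different one, so the expectation is a step back toward compound 1 rather than a full recovery of its number.

Compound 3 is therefore expected to give 15 nM in this assay, within a range of 5 nM to 50 nM, which corresponds to an estimated step of a 2.2-fold lower number from compound 2 to compound 3 (0.34 log units; beyond the scatter).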

Compound 3, half-maximal inhibitory concentration in the prostaglandin E2 receptor EP3 subtype assay: 200 nM
Beside the measured number, compound 3's estimate is 13-fold (1.12 log units) below it; the measured number lies above the stated range.
By their numbers in the prostaglandin E2 receptor EP3 subtype assay, from the lowest: compound 1; then compound 2; then compound 3.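

In the prostaglandin E2 receptor EP3 subtype assay, the new result shows that a larger group on this chain carbon does not by itself give stronger inhibition: a 6.1-fold higher number from compound 2 to compound 3 (0.78 log units; beyond the scatter), so benzyl, with 7 heavy atoms against 3 for cyclopropyl, goes the opposite way from the earlier step from cyclopropyl to cyclohexyl. The contrast between the two six-membered rings is wider still, with a 25-fold higher number from compound 1 to compound 3 (1.40 log units; beyond the scatter), which leaves compound 3 the weakest of the three and shows that this position tells benzyl sharply apart from cyclohexyl. In a physicochemical assay for solubility, measured as kinetic solubility, at pH 2 (a lower number here means a less soluble compound, a higher number a more soluble compound), compound 2 gives 3850 nM, and compound 3 gives 900 nM. The same change also goes with lower solubility in the physicochemical assay: the measured solubility of compound 2, 3850 nM, and of compound 3, 900 nM, a 4.3-fold lower number (0.63 log units; beyond the scatter)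

The compounds shown leave open whether the loss follows the aromatic ring or the extra carbon that carries it, since benzyl differs from cyclohexyl in both, and a directly attached phenyl and a cyclohexylmethyl group would be the groups to separate the two. They also leave open how cyclopentyl would compare with cyclopropyl and cyclohexyl on this chain carbon.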